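The source may hold more compounds than are shown below. What is called first, only, known or untested is meant among the compounds shown, and "the series" means these compounds.

Of the compounds shown here, three have been measured in a functional assay on cells (Splenocyte, Mus musculus, strain BALB/c) for inhibition, read by scintillation counting and thymidine incorporation, with stated times of 48 h and 8 h; a higher number here means a weaker inhibitor, a lower number a stronger inhibitor. Compound 1 `Fc1ccc(-c2noc(Cc3c[nH]c4ccccc34)n2)cc1` gives 5400 nM there. Compound 2 `COc1cc(-c2noc(-c3ccccc3)n2)cc(OC)c1OC` reaches only the limit of this assay, > 50000 nM, so no number is known for it. Compound 3 `COc1cc(-c2noc(-c3ccc(NC(=O)OC(C)(C)C)cc3)n2)cc(OC)c1OC` gives 1600 nM, the lowest of the two numbers shown, with compound 1 the only other compound that gives a number. Among the measured compounds shown here, the single step between measured compounds, an at least 31-fold lower number from compound 2 to compound 3 (1.49 log units; beyond the scatter), starts from a value at the limit (the limit of > 50000 nM in this assay, at which 1 of the 3 values shown sits), so its true size is only known as a minimum.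

Compound 4 `COc1cc(-c2noc(-c3ccc(N)cc3)n2)cc(OC)c1OC` differs from compound 3 in one place: hydrogen in place of tert-butoxycarbonyl on a nitrogen on an aromatic ring. For the measured compounds named here, no measured step covers this exact change. The nearest evidence is an at least 31-fold lower number from compound 2 to compound 3 (1.49 log units; beyond the scatter), where the whole (tert-butoxycarbonyl)amino group entered at once; compound 4 keeps the amino part but loses the tert-butoxycarbonyl part, and how much of that large gain came from the amino alone cannot be read from the data. Compound 4 is therefore expected to sit between the two, as a weaker inhibitor than compound 3, with a step of a 3.8-fold higher number from compound 3 to compound 4 (0.57 log units; beyond the scatter) expected in this assay. Compound 4 is thus estimated at 6000 nM, with a range from 1200 nM to 30000 nM.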

Compound 4, half-maximal inhibitory concentration: 800 nM
Compound 4: the middle estimate sits 7.5-fold (0.88 log units) above what was measured; measured number below the stated range.
By their numbers in this assay, from the lowest: compounds 4 and 3 (each within the scatter of the next); then compound 1. At a limit, above all of these: compound 2.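

In this assay, the tert-butoxycarbonyl part can leave the nitrogen on the aromatic ring with no change that stands out from the scatter: a 2.0-fold lower number from compound 3 to compound 4 (0.30 log units; within the scatter). The large gain first seen with the whole (tert-butoxycarbonyl)amino group therefore does not depend on the tert-butoxycarbonyl part, since amino alone on that aromatic carbon also gives a large step: an at least 62-fold lower number from compound 2 to compound 4 (1.79 log units; beyond the scatter). The true size of that step is known only as a minimum, because compound 2 stands at a limit and not at a number: the limit of > 50000 nM in this assay, at which 1 of the 4 values shown sits.

The compounds shown leave open whether the nitrogen itself matters, or whether another group on that aromatic carbon, such as a hydroxyl, a methyl or a carboxylic acid, would also give a number well clear of that limit. They also leave open what smaller groups on the nitrogen, such as a methyl or an acetyl, would do, and whether an amino group would bring a similar gain on the core of compound 1.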